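Swapping the aryl ether in a thromboxane synthase inhibitor

The source may report more compounds than this note shows. Statements on the series, on what has been measured and on what is new or still open speak of the compounds shown alone.

Compound 1: `O=C(O)CC/C=C\CC1COC(c2ccccc2Cl)OC1c1cccnc1` — 48 nM
Compound 2: `CSc1ccc(OC(C)(C)C2OCC(C/C=C\CCC(=O)O)C(c3cccnc3)O2)c([N+](=O)[O-])c1` — 22 nM

In an assay for inhibition of Thromboxane-A synthase (Homo sapiens), using microsomes (a higher number here means a weaker inhibitor, a lower number a stronger inhibitor), compound 2 gives 22 nM, the lowest of the two numbers measured; its nearest neighbour is compound 1, which gives 48 nM, a difference that lies beyond the usual scatter. Among the measured compounds shown here, compound 1 and compound 2 do not differ in a single place, so no step between them is counted.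

Compound 3, `CC(C)(Oc1ccccc1F)C1OCC(C/C=C\CCC(=O)O)C(c2cccnc2)O1`, differs from compound 2 in one place: a group of 7 heavy atoms (6 carbon, 1 fluorine; one six-membered aromatic ring of carbon only) in place of a group of 11 heavy atoms (7 carbon, 1 nitrogen, 2 oxygen, 1 sulfur; one six-membered aromatic ring of carbon only), on an oxygen on a saturated carbon. The acid chain, the double bond outside aromatic rings, the pyridine-bearing core and the oxygen on a saturated carbon carrying the aryl group are all kept.

For the measured compounds named here, only two measured numbers are available and neither is a single-place step, so there is no counted precedent for this exchange. The expectation is that compound 3 stays within or close to the scatter of compound 2 in this assay, with the step of a 1.4-fold higher number from compound 2 to compound 3 (0.13 log units; within the scatter) estimated as small, if anything toward a slightly higher number. Compound 3 is estimated at 30 nM, within a range of 10 nM to 90 nM.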

Compound 3, half-maximal inhibitory concentration: 45 nM
For compound 3 the middle estimate is 1.5-fold (0.18 log units) below the measured one; the range from low to high includes it.
By their numbers in this assay, from the lowest: compound 2; then compounds 3 and 1 (each within the scatter of the next).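

Among the compounds shown here, the exchange gives the first counted step at this place, on an oxygen on a saturated carbon: in this assay, putting 2-fluorophenyl in place of the group of 11 heavy atoms gives a 2.0-fold higher number from compound 2 to compound 3 (0.31 log units; beyond the scatter), a modest change that lies beyond the scatter. Both groups hold one six-membered aromatic ring of carbon only, so the change here is in what that ring carries, and the acid chain and the rest of the molecule stay the same. Which of the atoms that leave accounts for the step cannot be told from this single exchange, and no measurement at hand explains it.

The compounds shown leave open how a methoxy group or an amine would read on the phenyl ring in place of the fluorine, and whether the group of 11 heavy atoms owes its number to one of its substituents or to both together. They also leave open whether the same exchange would give a step of similar size on a longer chain in place of the present acid chain.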